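Swapping Pyridin-2-yl for 3-Hydroxyphenyl on the Chain

The compounds below may be only part of what the source reports. "The series", "measured", "known", "first", "only" and "open" are said of these compounds alone.

Of the compounds shown here, three sharing one core have been measured in an assay on isolated protein for inhibition of Retinaldehyde dehydrogenase 3 (Homo sapiens); a higher number here means a weaker inhibitor, a lower number a stronger inhibitor. Compound 1 `CC(Sc1nc2c(cnn2C)c(=O)n1-c1ccccc1)c1ccccn1` gives 89 nM, the lowest of the three numbers. Compound 2 `Cn1ncc2c(=O)n(-c3ccccc3)c(COc3cccc(F)c3)nc21` gives 780 nM, and compound 3 `CC(Sc1nc2c(cnn2C)c(=O)n1-c1ccc(CO)cc1)c1ccccc1` gives 1000 nM; both gaps to compound 1 lie beyond the usual scatter, so compound 1 stands as the strongest inhibitor of this set. For the measured compounds named here, compounds 2 and 3 each differ from compound 1 in more than one place, so no single-change step is available among the measured compounds.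

Compound 4 `CC(Sc1nc2c(cnn2C)c(=O)n1-c1ccccc1)c1cccc(O)c1` has not yet been measured. It differs from compound 1 in one place: 3-hydroxyphenyl in place of pyridin-2-yl on a saturated chain carbon bound to a saturated chain carbon and a sulfur. This chain position has not been varied on its own among the measured compounds, so the size of the step can only be estimated. A modest weakening, at the edge of the scatter, is expected, with the step of a 2.2-fold higher number from compound 1 to compound 4 (0.35 log units; beyond the scatter) the expected outcome. Compound 4 is expected to give 200 nM, within a range of 60 nM to 700 nM.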

Compound 4, half-maximal inhibitory concentration: 91 nM
The estimate for compound 4 lay 2.2-fold (0.34 log units) above the measured number, and the stated range covers the measured number.
By their numbers in this assay, from the lowest: compounds 1 and 4 (each within the scatter of the next); then compounds 2 and 3 (each within the scatter of the next).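

In this assay, for the compounds shown here, this is the first change at this chain position that can be read on its own, and the result is a 1.0-fold higher number from compound 1 to compound 4 (0.01 log units; within the scatter). Within this pair, pyridin-2-yl, with no hydrogen-bond donor and a ring nitrogen, and 3-hydroxyphenyl, with one hydrogen-bond donor and a ring of carbon only, cannot be told apart by their numbers, so the ring nitrogen of compound 1 is not required to keep its level of inhibition. No supporting data bear on why the two groups match.

A single pair cannot show how far this tolerance extends, for instance to a carboxylic acid or an amine on the ring, or to a saturated cyclohexyl ring in its place. On these data alone, how compounds 2 and 3 come to their numbers also stays open, as each differs from compound 1 in more than one place.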